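Two-Chlorophenyl for Trifluoromethylphenyl: Expected Cytotoxicity Step

This account rests on a few compounds, and the source may have more. Where it says the series, first, only, none or still open, it means among the compounds named here.

Compound 3 `Cc1cc(S(=O)(=O)/N=C(\N)n2nccc2-c2ccccc2)c(SCc2cccc(C(F)(F)F)c2)cc1Cl` is one of three compounds that share a common core and differ only in the group on the saturated chain carbon bound to a sulfur. In an ADME assay on HaCaT cells (Homo sapiens) for cytotoxicity, read by MTT assay, with a stated time of 72 h (a lower number here means a stronger inhibitor, a higher number a weaker inhibitor), compound 3 gives 18000 nM. Compound 1 `Cc1cc(S(=O)(=O)/N=C(\N)n2nccc2-c2ccccc2)c(SCc2ccccc2)cc1Cl` lacks the trifluoromethyl, and in this assay compound 1 gives 18000 nM. Compound 2 `Cc1cc(S(=O)(=O)/N=C(\N)n2nccc2-c2ccccc2)c(SCc2ccc(C(F)(F)F)cc2)cc1Cl` carries the trifluoromethyl as a 4-(trifluoromethyl)phenyl, and in this assay compound 2 gives 19000 nM. Compound 3 is level with compound 1 at the digits shown, the two together the lowest of the three numbers; the nearest step is no change at the digits printed from compound 1 to compound 3 (within the scatter), the furthest a 1.1-fold lower number from compound 2 to compound 3 (0.02 log units; within the scatter).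

Compound 4 `Cc1cc(S(=O)(=O)/N=C(\N)n2nccc2-c2ccccc2)c(SCc2ccccc2Cl)cc1Cl` is not yet measured. The change is 2-chlorophenyl in place of 3-(trifluoromethyl)phenyl on a saturated chain carbon bound to a sulfur. For the measured compounds named here, three steps bear on it: a 1.1-fold lower number from compound 2 to compound 3 (0.02 log units; within the scatter) moved the trifluoromethyl around the ring, while a 1.1-fold higher number from compound 1 to compound 2 (0.02 log units; within the scatter) and no change at the digits printed from compound 1 to compound 3 (within the scatter) introduced it; none reached beyond the scatter. Going by the values given here, since every change at this position so far left this assay unmoved, compound 4 is expected to show no step beyond the scatter, no change at the digits printed from compound 3 to compound 4 (within the scatter). The estimate for compound 4 is therefore 18000 nM, with a range from 9000 nM to 36000 nM.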

Compound 4, half-maximal inhibitory concentration: 20000 nM
Beside the measured number, compound 4's estimate is 1.1-fold (0.05 log units) below it; the range from low to high includes it.
By their numbers in this assay, from the lowest: compounds 1, 3, 2 and 4 (each within the scatter of the next).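

The earlier compounds shown here carried only hydrogen or trifluoromethyl on this ring, and compound 4 extends the reading to a chloro-bearing ring. In this assay the new group gives a 1.1-fold higher number from compound 3 to compound 4 (0.05 log units; within the scatter) and a 1.1-fold higher number from compound 2 to compound 4 (0.02 log units; within the scatter) as well as a 1.1-fold higher number from compound 1 to compound 4 (0.05 log units; within the scatter) in turn, so neither trifluoromethyl placement differs from the 2-chlorophenyl beyond the scatter. Exchanging the 10 heavy atoms of 3-(trifluoromethyl)phenyl for the 7 of 2-chlorophenyl on a saturated chain carbon bound to a sulfur thus leaves the read-out within the scatter, and none of the four compounds goes against this flat pattern, though no measurement shown here offers an explanation for it.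

All four groups are phenyl rings bearing only hydrogen, trifluoromethyl or chloro, so the compounds shown leave open whether this flat response would hold for a ring carrying an amine or a carboxylic acid. They also leave open what a longer chain between the sulfur and the ring would do in this assay, or whether a group with no ring at all would stay within the scatter.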